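The source may report more compounds than this note shows. Statements on the series, on what has been measured and on what is new or still open speak of the compounds shown alone.

Three compounds have been measured in a functional assay on CHO cells with adenosine receptor A1 (Homo sapiens) as the target, read by cAMP accumulation and immunoassay, with a stated time of 6 min, tested at 0.01 uM; a lower number here means a stronger effect, a higher number a weaker effect of the compound at the concentration tested:

Compound 1, `COc1ccc(N2CCN(Cc3csc(N)c3C(=O)c3ccc(Cl)cc3)CC2)cc1`, gives -1.2%.
Compound 2, `Nc1scc(CN2CCN(c3cccc4ccccc34)CC2)c1C(=O)c1ccc(Cl)cc1`, gives 8.7%.
Compound 3, `Nc1scc(CN2CCN(c3ccccc3F)CC2)c1C(=O)c1ccc(Cl)cc1`, gives 2.1%.

All three numbers sit close to zero, and none can be told from the others: the step of a number 3.3 percentage points higher from compound 1 to compound 3 (within the scatter) and the step of a number 9.9 percentage points higher from compound 1 to compound 2 (within the scatter) are both within the scatter, as is the step of a number 6.6 percentage points lower from compound 2 to compound 3 (within the scatter). Compound 1 therefore stands level with its two companions, not apart from them.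

Compound 4, `Nc1scc(CN2CCN(CCCc3ccc(Cl)cc3)CC2)c1C(=O)c1ccc(Cl)cc1`, differs from compound 1 in one place: 3-(4-chlorophenyl)propyl in place of 4-methoxyphenyl on an amine nitrogen in a ring. The measured steps all swap one aromatic group for another on that ring nitrogen, and each stayed within the scatter; none puts a chain of the kind that enters here onto that nitrogen, so they bear on the change only loosely. Within the data shown here, since every swap at this position so far has left the number unmoved, no step beyond the scatter is expected from the step of a number 4.2 percentage points higher from compound 1 to compound 4 (within the scatter). Compound 4 is estimated at 3%, within a range from -10% to 16%.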

Compound 4, a percentage reported as activity, at one concentration (the size of the read-out at that concentration, not a potency): 0%
For compound 4 the middle estimate is 3 percentage points above the measured one; low and high end bracket the measured number.
By their numbers in this assay, from the lowest: compounds 1, 4, 3 and 2 (each within the scatter of the next).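

Until now, every group on the amine nitrogen in a ring was an aromatic one, so the flat response in this assay might have held for that kind of group alone. Among these compounds, compound 4 carries 3-(4-chlorophenyl)propyl there, a chain ending in an aromatic ring, and still no step leaves the scatter: (a number 1.2 percentage points higher from compound 1 to compound 4 (within the scatter)), (a number 2.1 percentage points lower from compound 3 to compound 4 (within the scatter)) and (a number 8.7 percentage points lower from compound 2 to compound 4 (within the scatter)). The position thus tolerates this chain as well as the aromatic groups without any readable change in the number, and nothing measured explains why.

From the compounds shown here alone, every group here still contains an aromatic ring, so a plain alkyl chain, or a chain ending in a carboxylic acid or an amine, remains untested in these compounds. Going by these compounds, whether any group on this nitrogen can move the number beyond the scatter also stays open.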